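Biaryl Amides as Mouse Nicotinamide Phosphoribosyltransferase Inhibitors

The compounds below may be only part of what the source reports. "The series", "measured", "known", "first", "only" and "open" are said of these compounds alone.

Measured compounds:
compound 1, `O=C(O)c1ccccc1-c1ccccc1C(=O)NCCCCCCCn1cc(-c2cccnc2)nn1`, 38.5 nM
compound 2, `NC(=O)c1ccccc1-c1ccccc1C(=O)NCCCCCCCn1cc(-c2cccnc2)nn1`, 87.9 nM
compound 3, `O=C(O)c1ccc(-c2ccccc2C(=O)NCCCCCCCn2cc(-c3cccnc3)nn2)cc1`, > 500 nM

The three compounds share one core and differ only in the aryl group attached to it. In an assay for inhibition of Nicotinamide phosphoribosyltransferase (Mus musculus), read by fluorescence, with a stated time of 1 h, in the presence of a further agent that is not named here (a lower number here means a stronger inhibitor, a higher number a weaker inhibitor), compound 1 gives 38.5 nM. Compound 2 gives 87.9 nM in this assay, a 2.3-fold higher number from compound 1 to compound 2 (0.36 log units; beyond the scatter). For compound 3 this assay gives only a limit, > 500 nM, so that compound 3 stands at the limit of > 500 nM in this assay, at which 1 of the 3 values shown sits, and its true value is not known. The step of an at least 12-fold higher number from compound 1 to compound 3 (1.11 log units; beyond the scatter) was large, the step of an at least 5.6-fold higher number from compound 2 to compound 3 (0.75 log units; beyond the scatter) at least modest.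

Compound 4, `O=C(NCCCCCCCn1cc(-c2cccnc2)nn1)c1ccccc1-c1cccnc1`, is not yet measured. It differs from compound 3 by pyridin-3-yl in place of 4-carboxyphenyl on an aromatic carbon. Among the compounds with values here, none of the measured steps removes the carboxylic acid altogether, so only the size of the steps to compound 3 offers a guide, and the limit for compound 3 leaves the direction open. Compound 4 is estimated to give 250 nM in this assay, within 50 nM to 1500 nM, which would mean an expected step of an at least 2.0-fold lower number from compound 3 to compound 4 (0.30 log units; that floor lies within the scatter).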

Compound 4, half-maximal inhibitory concentration: 28.5 nM
Beside the measured number, compound 4's estimate is 8.8-fold (0.94 log units) above it, outside the stated range (below it).
By their numbers in this assay, from the lowest: compounds 4 and 1 (each within the scatter of the next); then compound 2. At a limit, above all of these: compound 3.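

In this assay, pyridin-3-yl at this position shows that neither a carboxylic acid nor a carbamoyl group is required on the group attached here: the change gives a 1.4-fold lower number from compound 1 to compound 4 (0.13 log units; within the scatter), and a 3.1-fold lower number from compound 2 to compound 4 (0.49 log units; beyond the scatter). Against the 4-carboxyphenyl group, the same replacement gives an at least 17-fold lower number from compound 3 to compound 4 (1.24 log units; beyond the scatter), so a single six-membered aromatic ring with one hetero atom serves here in place of either carbonyl-bearing phenyl group. The value of compound 3 is only a limit: the limit of > 500 nM in this assay, at which 1 of the 4 values shown sits.

The compounds shown leave open whether the ring nitrogen of pyridin-3-yl matters at all, as a plain phenyl group stands nowhere among them. They also leave open whether pyridin-4-yl, or a shorter chain with pyridin-3-yl kept in place, would give a similar number.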